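Chloro added to compound 2: expected growth inhibition

The compounds below may be only part of what the source reports. "The series", "measured", "known", "first", "only" and "open" are said of these compounds alone.

Compound 1 `COc1cc(-c2nn(-c3cccc(NC(=O)c4ccc(Cl)c(C(F)(F)F)c4)c3)cc2-c2ccncc2)ccc1Cl` in a functional assay on SK-OV-3 cells (Homo sapiens) for inhibition, read by sulforhodamine B assay, with a stated time of 48 h (a lower number here means a stronger inhibitor of growth, a higher number a weaker inhibitor of growth), gives only a limit, > 32500 nM. Compound 2 `COc1cc(-c2nn(-c3cccc(NC(=O)Nc4cccc(C(F)(F)F)c4)c3)cc2-c2ccncc2)ccc1Cl` in this assay likewise returns only a limit, > 50000 nM. The step that the two limits leave unreadable from compound 1 to compound 2 therefore cannot be read, since both ends sit at limits (the limit of > 32500 nM in this assay, at which 1 of the 2 values shown sits, and (the limit of > 50000 nM in this assay, at which 1 of the 2 values shown sits)). Compound 3 `COc1cc(-c2nn(-c3cccc(NC(=O)Nc4ccc(Cl)c(C(F)(F)F)c4)c3)cc2-c2ccncc2)ccc1Cl` differs from compound 2 by chloro in place of hydrogen on an aromatic carbon. Among the measured compounds shown here, no measured step in this set is readable, so no step beyond the scatter can be expected in this assay, and a further limit is the likely outcome. Compound 3 is expected near 50000 nM, within 15000 nM to 150000 nM. The expected step is a number no higher from compound 2 to compound 3 (the limit leaves the size open).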

Compound 3, concentration for total growth inhibition: 13000 nM
Estimate against measurement, compound 3: 3.8-fold (0.59 log units) above; the measured number lies below the stated range.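

Chloro on the aromatic carbon ortho to the trifluoromethyl group brings a readable value into this assay, with an at least 3.8-fold lower number from compound 2 to compound 3 (0.58 log units; beyond the scatter) as the step at this position. With that chloro kept, the linking amino on the carbonyl carbon also matters, as an at least 2.5-fold lower number from compound 1 to compound 3 (0.39 log units; beyond the scatter) shows for (4-chloro-3-(trifluoromethyl)phenyl)amino in place of 4-chloro-3-(trifluoromethyl)phenyl. Both sizes are lower bounds, and the full size of neither step can be read.

On these data alone, whether fluoro, methyl or a dimethylamino group on that same carbon would serve as chloro does remains open. Nothing shown gives a cause for either step.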